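The source may hold more compounds than are shown below. What is called first, only, known or untested is meant among the compounds shown, and "the series" means these compounds.

Compound 3 `COC(=O)c1ccc(C(=O)Nc2ccc(-c3ccc(C(=O)Nc4cccc5cccc(S(=O)(=O)O)c45)cc3)cc2)cc1` is the reference point of this small set. In an assay on isolated protein for inhibition of CD40-CD40L (Homo sapiens), read by ELISA, with a stated time of 1 h (a lower number here means a stronger inhibitor, a higher number a weaker inhibitor), compound 3 gives 170 nM, the lowest of the three numbers obtained so far. Compound 1 `O=C(Nc1ccc(-c2ccc(C(=O)Nc3ccc(S(=O)(=O)O)c4ccccc34)cc2)cc1)c1ccc([N+](=O)[O-])cc1` gives 2330 nM in this assay, and compound 2 `O=C(Nc1ccc(C(=O)Nc2cccc3cccc(S(=O)(=O)O)c23)cc1)c1ccc([N+](=O)[O-])cc1` gives 342000 nM; both gaps to compound 3 lie beyond the scatter, so compound 3 is the strongest inhibitor among the measured compounds.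

Compound 4 `O=C(Nc1ccc(-c2ccc(C(=O)Nc3cccc4cccc(S(=O)(=O)O)c34)cc2)cc1)c1ccc([N+](=O)[O-])cc1` has not yet been measured. It differs from compound 3 in a single place: nitro in place of methoxycarbonyl on an aromatic carbon, para to a large group. Among the measured compounds shown here, no measured pair shows this exact exchange, so the size of its effect is open. Compound 1 also carries a nitro group and stands in this assay at 2330 nM, but it is not a one-step neighbour of compound 4 and serves only as a loose pointer. The step from compound 3 to compound 4 is expected to be a modest weakening, a 2.4-fold higher number from compound 3 to compound 4 (0.37 log units; beyond the scatter), at the edge of the scatter. Compound 4 is therefore estimated at about 400 nM in this assay, with a likely range from 120 nM to 1500 nM.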

Compound 4, half-maximal inhibitory concentration in the CD40-CD40L assay: 310 nM
Compound 4: middle estimate off by 1.3-fold (0.11 log units), on the high side, within the range that was stated.
By their numbers in the CD40-CD40L assay, from the lowest: compounds 3 and 4 (each within the scatter of the next); then compound 1; then compound 2.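

Among the compounds shown here, this is the first step in the set that changes only one place. In the CD40-CD40L assay, nitro in place of methoxycarbonyl on an aromatic carbon, para to a large group, gives a 1.8-fold higher number from compound 3 to compound 4 (0.26 log units; within the scatter), so this assay does not separate the two groups at this position. In a physicochemical assay for solubility (a higher number here means a more soluble compound, a lower number a less soluble compound), by contrast, compound 3 gives 240000 nM and compound 4 gives 7000 nM. In the physicochemical assay the same exchange separates the two compounds widely, with the nitro compound on the lower side: the measured solubility of compound 3, 240000 nM, and of compound 4, 7000 nM, a 34-fold lower number (1.54 log units; beyond the scatter).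

The compounds shown leave open whether another group at this position, such as a carboxylic acid or a nitrile, would keep the number in the CD40-CD40L assay close to those of compound 3 and compound 4 while matching the solubility of compound 3. On these data alone, whether the exchange reads the same on the core of compound 1 or compound 2 also remains open.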